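The source may hold more compounds than are shown below. What is called first, only, known or untested is meant among the compounds shown, and "the series" means these compounds.

Measured compounds:
- compound 1 `CCN1CCN(c2nc(Nc3ccc(C#N)c(C(F)(F)F)c3)nc(Oc3ccnc4ccccc34)n2)CC1`: > 100000 nM
- compound 2 `COc1ccc(CN2CCN(c3nc(Nc4ccc(C#N)c(C(F)(F)F)c4)nc(Oc4ccnc5ccccc45)n3)CC2)c(OC)c1OC`: > 100000 nM
- compound 3 `N#Cc1ccc(Nc2nc(Oc3ccnc4ccccc34)nc(N3CCCCC3)n2)cc1C(F)(F)F`: > 100000 nM

In a functional assay on DU-145 cells (Homo sapiens) for cytotoxicity, read by sulforhodamine B assay, with a stated time of 48 h (a lower number here means that less compound is tolerated, a higher number that more compound is tolerated), compound 1 gives only a limit, > 100000 nM, not a number. Compound 2 likewise reaches only a limit in this assay, > 100000 nM. Compound 3 too gives only a limit, > 100000 nM. Going by the values given here, compound 1 thus stands where every value so far stands, at the limit of > 100000 nM in this assay, at which 3 of the 3 values shown sit, so no compound can be called more or less tolerated than another.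

Compound 4 `N#Cc1ccc(Nc2nc(Oc3ccnc4ccccc34)nc(N3CCN(c4cccc(Cl)c4Cl)CC3)n2)cc1C(F)(F)F` differs from compound 1 in one place: 2,3-dichlorophenyl in place of ethyl on an amine nitrogen in a ring. The two measured steps that start from compound 1 are the nearest guides. The step from compound 1 to compound 2 is a step that the two limits leave unreadable from compound 1 to compound 2, and the step from compound 1 to compound 3 is a step that the two limits leave unreadable from compound 1 to compound 3; both ends of each sit at the limit, so neither step reveals a size or a direction. Nothing measured therefore points to a change beyond the scatter for this assay when the group on the ring nitrogen is exchanged again.

Compound 4 is accordingly expected to give about 100000 nM in this assay, within a range from 20000 nM to 300000 nM. The estimated step is a number no higher from compound 1 to compound 4 (the limit leaves the size open).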

Compound 4, concentration lethal to 50% of the cells: > 100000 nM
Compound 4 gave a limit, no number; the forecaster's own chance of this, stated with the estimate: 65%; the middle value sits exactly at the limit.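

Compound 4 gives > 100000 nM in this assay, which is a limit and not a number. Compound 1 also gives only a limit, so no step can be read from compound 1 to compound 4. The compounds shown leave open whether exchanging the group on the ring nitrogen changes the lethal concentration at all, as every result is the same limit: the limit of > 100000 nM in this assay, at which 4 of the 4 values shown sit.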